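A few compounds are considered here, and "the series" means these few. Any claim that something is new, unique, unknown or untested is made for them only; others in the source may bear on it.

The series shares one core, carried by compound 1 `CC(C)CCn1ccc(-c2ccccc2)c(C#N)c1=O`, compound 2 `CNc1ccc(-c2ccn(CCC(C)C)c(=O)c2C#N)cc1` and compound 3 `Cc1cc(Oc2ccc(-c3ccn(CC4CCC4)c(=O)c3C#N)cc2)ccn1`. In a functional assay on CHO cells for positive allosteric modulation of metabotropic glutamate receptor 2 (Homo sapiens), read by scintillation counting and GTPgammaS binding, with a stated time of 30 min (on this read-out lower numbers stand for smaller maximal responses and higher numbers for larger maximal responses), compound 1 gives 117%. Among the measured compounds shown here, compound 2 gives 186% in this assay, and the only step recorded between measured compounds that differ in one place, a number 69 percentage points higher from compound 1 to compound 2 (beyond the scatter), comes from methylamino in place of hydrogen on an aromatic carbon. Compound 3 gives 233% in this assay, the highest of the three numbers; it stands beyond the scatter above compound 2 and further still above compound 1. The next compound, compound 4 `Cc1cc(Oc2ccc(-c3ccn(CC4CC4)c(=O)c3C#N)cc2)ccn1`, differs from compound 3 in one place: cyclopropyl in place of cyclobutyl on a saturated chain carbon bound to an aromatic nitrogen. For the measured compounds named here, no measured step touches the group on the saturated chain carbon bound to the aromatic nitrogen; the one step shown sits on an aromatic carbon and says only how large a single change can be in this assay. With nothing pointing in either direction, the account expects a step in this assay of about a number 13 percentage points lower from compound 3 to compound 4 (beyond the scatter), small and not clearly beyond the scatter. Compound 4 is therefore estimated to give 220% in this assay, with a range from 170% to 270%.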

Compound 4, largest response reached (Emax), in percent of the reference or control that the assay uses: 199%
The estimate for compound 4 lay 21 percentage points above the measured number, within the range that was stated.
By their numbers in this assay, from the lowest: compound 1; then compound 2; then compound 4; then compound 3.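

In this assay, cyclopropyl in place of cyclobutyl on a saturated chain carbon bound to an aromatic nitrogen gives a number 34 percentage points lower from compound 3 to compound 4 (beyond the scatter) and is the first step shown at this position. The earlier step, on an aromatic carbon, said nothing about this place; this one shows that the response also depends on the group held here, and that a single ring carbon is enough to move it beyond the scatter, even though neither group has any hydrogen-bond donors or acceptors or a net charge. Nothing at hand explains why the smaller ring gives the lower number.

The compounds shown give only two ring sizes at this position, so they cannot tell whether the response would keep rising with a cyclopentyl group, or how an open chain, an amine or a carboxylic acid would behave there. They also leave open whether the same exchange would give a step of similar size on a compound carrying methylamino on the aromatic ring, as compound 2 does, in place of the ether-linked methylpyridine-type group of compound 3 and compound 4.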